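The source may report more compounds than this note shows. Statements on the series, on what has been measured and on what is new or still open speak of the compounds shown alone.

Of the compounds shown here, three have been measured in a functional assay on HCT-116 cells (Homo sapiens) for antiproliferative activity, read by CellTiter-Glo, with a stated time of 72 h; a lower number here means a stronger inhibitor, a higher number a weaker inhibitor. There compound 1 `O=C(NO)c1cccc(/C=C/c2ccnc(-c3cc(F)ccc3O)c2)c1` gives 3890 nM and compound 2 `O=C(NO)c1ccc(/C=C/c2ccnc(-c3cccnc3)c2)cc1` gives 5140 nM, two values within the usual scatter of each other. In this assay compound 3 `O=C(NO)c1ccc(/C=C/c2cccc(-c3cccc(O)c3)c2)cc1` gives > 10000 nM, and this is a limit of the assay and not a number. Compound 3 therefore has no exact place on the scale. Compound 4 `O=C(NO)c1ccc(/C=C/c2cccc(-c3cc(F)ccc3O)c2)cc1` departs from it in one group: 5-fluoro-2-hydroxyphenyl in place of 3-hydroxyphenyl on an aromatic carbon, meta to a large group (5-fluoro-2-hydroxyphenyl in place of 3-hydroxyphenyl on an aromatic carbon). Going by the values given here, no step between measured compounds sizes this change directly. Among the compounds with values here, the only guide is compound 1, which carries the same 5-fluoro-2-hydroxyphenyl on a different core and gives 3890 nM. A move toward stronger inhibition is therefore expected, though compound 4 could also end up at the limit of the assay. From the compounds shown here alone, the expected change is an at least 2.2-fold lower number from compound 3 to compound 4 (0.34 log units; beyond the scatter), an estimated figure whose true size stays open while the starting point is only a limit. In this assay the estimated value for compound 4 is 4500 nM, with an expected range from 1500 nM to 12000 nM.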

Compound 4, half-maximal inhibitory concentration: > 10000 nM
Compound 4 was reported as a limit (the forecaster's own chance of this, stated with the estimate: 30%); at least 2.2-fold (0.34 log units) between middle value and limit.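

In this assay compound 4 gives > 10000 nM as a limit of the assay and not a number. Going by these compounds alone, compound 3 also stands at a limit, so no step from compound 3 to compound 4 can be read: the limit of > 10000 nM in this assay, at which 2 of the 4 values shown sit. The compounds shown leave open whether 5-fluoro-2-hydroxyphenyl in place of 3-hydroxyphenyl on this core changes the activity at all, and in which direction.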